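Carboxy in Place of Hydroxymethyl from an Unreadable Start

This account rests on a few compounds, and the source may have more. Where it says the series, first, only, none or still open, it means among the compounds named here.

Measured so far in a functional assay on MOLT-3 cells (Homo sapiens) for cytotoxicity, read by MTT assay, with a stated time of 72 h; a higher number here means a weaker inhibitor, a lower number a stronger inhibitor:
Compound 1, `CC(=O)O[C@H](C/C(C)=C/CO)[C@@]1(C)[C@H](C)CC=C2[C@@H]1CCCC2(C)C`, gives > 30000 nM, which is a limit of the assay.
Compound 2, `CCC(=O)OC/C=C(\C)C[C@@H](O)[C@@]1(C)[C@H](C)CC=C2[C@@H]1CCCC2(C)C`, gives > 30000 nM, which is a limit of the assay.
Compound 3, `C/C(=C\CO)C[C@@H](O)[C@@]1(C)[C@H](C)CC=C2[C@@H]1CCCC2(C)C`, gives > 30000 nM, which is a limit of the assay.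

Compound 1 therefore stands only at a bound, not at a number, and every value shown sits there, as the limit of > 30000 nM in this assay, at which 3 of the 3 values shown sit, records. The steps a step that the two limits leave unreadable from compound 1 to compound 3 and a step that the two limits leave unreadable from compound 2 to compound 3 are unreadable between two limits, and neither touches the change now considered. Compound 4, `CC(=O)O[C@H](C/C(C)=C/C(=O)O)[C@@]1(C)[C@H](C)CC=C2[C@@H]1CCCC2(C)C`, differs from compound 1 by carboxy in place of hydroxymethyl on a double-bonded chain carbon bound to a double-bonded chain carbon. For the measured compounds named here, no measured step bears on this change, so no direction can be drawn from the data. The expectation is simply the step that the limit leaves unreadable from compound 1 to compound 4. Compound 4 is expected to give about 40000 nM, within 10000 nM to 150000 nM, most likely again reported only as a limit.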

Compound 4, half-maximal inhibitory concentration: > 30000 nM
Compound 4: no number, only a limit; the forecaster's own chance of this, stated with the estimate: 80%; the middle value is on the limit's open side.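

Compound 4 also gives only a limit, > 30000 nM, so no step can be read from compound 1 to compound 4. The compounds shown leave open whether carboxy in place of hydroxymethyl changes anything in this assay, since no actual number is available on either side.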